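The source may report more compounds than this note shows. Statements on the series, on what has been measured and on what is new or still open speak of the compounds shown alone.

Compound 1 `N[C@@H](COP(=O)(O)OCCCOC(=O)CCc1ccccc1OCc1cccc(Oc2ccc(Cl)c(Cl)c2)c1)C(=O)O` gives 18% in an assay on cells for agonist activity at probable G-protein coupled receptor 34 (Mus musculus), with a stated time of 1 h; a higher number here means a larger maximal response, a lower number a smaller maximal response. Compound 2 `CCc1ccc(Oc2cccc(COc3ccccc3CCC(=O)OCCCOP(=O)(O)OC[C@H](N)C(=O)O)c2)cc1` gives 19.3%. Compound 3 `CC(C)(C)c1cccc(Oc2cccc(COc3ccccc3CCC(=O)OCCCOP(=O)(O)OC[C@H](N)C(=O)O)c2)c1` gives 19.9%.

On these numbers compound 3 stands highest of the three, yet the gaps are small: a number 0.6 percentage points higher from compound 2 to compound 3 (within the scatter) and a number 1.9 percentage points higher from compound 1 to compound 3 (within the scatter), both within the scatter. Compound 4 `CC(C)(C)c1ccc(Oc2cccc(COc3ccccc3CCC(=O)OCCCOP(=O)(O)OC[C@H](N)C(=O)O)c2)cc1` changes only the group on that same oxygen: 4-(tert-butyl)phenyl in place of 3-(tert-butyl)phenyl on an oxygen on an aromatic ring. Among the compounds with values here, every measured step so far has exchanged this group, and each stayed within the scatter: a number 1.3 percentage points higher from compound 1 to compound 2 (within the scatter), a number 1.9 percentage points higher from compound 1 to compound 3 (within the scatter), a number 0.6 percentage points higher from compound 2 to compound 3 (within the scatter). Three exchanges at this place left the largest response essentially unchanged, so no step beyond the scatter is expected here either, and the expected step is a number 0.1 percentage points higher from compound 3 to compound 4 (within the scatter). Compound 4 is therefore estimated to give 20% in this assay, likely between 14% and 26%.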

Compound 4, largest response reached (Emax), in percent of the reference or control that the assay uses: 16.9%
The estimate for compound 4 lay 3.1 percentage points above the measured number, and the stated range covers the measured number.
By their numbers in this assay, from the lowest: compounds 4, 1, 2 and 3 (each within the scatter of the next).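

Swapping 3-(tert-butyl)phenyl for its isomer 4-(tert-butyl)phenyl on this oxygen does not separate the two compounds (a number 3 percentage points lower from compound 3 to compound 4 (within the scatter)), so these two placements of the tert-butyl group cannot be told apart by largest response. The same holds for tert-butyl in place of ethyl (a number 2.4 percentage points lower from compound 2 to compound 4 (within the scatter)) and for 4-(tert-butyl)phenyl in place of 3,4-dichlorophenyl (a number 1.1 percentage points lower from compound 1 to compound 4 (within the scatter)). No evidence is available that bears on this result.

On these data alone, it remains open whether an amine or a carboxylic acid on this outer phenyl ring would give a response beyond the scatter.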